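Fluoro in place of chloro on compound 3

The source may hold more compounds than are shown below. What is called first, only, known or untested is meant among the compounds shown, and "the series" means these compounds.

Compound 1 `c1ccc(Cn2cnc3cncnc32)cc1` gives 33% in a functional assay on the whole organism for inhibition, with Rattus norvegicus as the target, in the maximal electroshock model, at a dose of 25 mg/kg by the intraperitoneal route; a lower number here means less inhibition, a higher number more inhibition at the dose given (going by the name of the read-out). Going by the values given here, compound 2 `c1ccc(Cn2cnc3c(Nc4ccccc4)ncnc32)cc1` gives 0%, and the one step measured so far, a number 33 percentage points lower from compound 1 to compound 2 (beyond the scatter), is anilino in place of hydrogen on an aromatic carbon. Compound 3 `CN(C)c1ncnc2c1ncn2Cc1ccc(Cl)cc1` gives 0%, level with compound 2 at the digits shown and together with it the lowest of the three numbers; against compound 1 it stands lower, beyond the scatter.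

Compound 4 `CN(C)c1ncnc2c1ncn2Cc1ccc(F)cc1` is not yet measured. It differs from compound 3 by fluoro in place of chloro on an aromatic carbon. Among the compounds with values here, no measured step touches a halogen on that ring; the only step, a number 33 percentage points lower from compound 1 to compound 2 (beyond the scatter), concerns a different part of compound 1 and does not bear on a halogen swap. With nothing to point either way, and compound 3 already at the floor of the read-out, no step beyond the scatter is expected: the estimated step is a number 3 percentage points higher from compound 3 to compound 4 (within the scatter). For compound 4 the value is estimated at 3%, with a range from 0% to 15%.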

Compound 4, a percentage reported as inhibition, in the whole organism at one dose (the size of the read-out at that dose, not a potency): 33%
Compound 4: middle estimate off by 30 percentage points, on the low side, outside the stated range (above it).
By their numbers in this assay, from the lowest: compounds 2 and 3 (each within the scatter of the next); then compounds 1 and 4 (each within the scatter of the next).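

On the aromatic carbon para to a large group, the choice of halogen matters in this assay: fluoro in place of chloro gives a number 33 percentage points higher from compound 3 to compound 4 (beyond the scatter). The exchange swaps one heavy atom for another, with no ring, hydrogen-bond donor, hydrogen-bond acceptor or net charge entering or leaving, so the read-out here is sensitive to a very small change at this place on the six-membered aromatic ring of carbon only. The dimethylamino group shared by compound 3 and compound 4 therefore does not by itself fix the read-out at the low value, and no measurement at hand accounts for the step.

Still open, as far as these compounds go, is what bromo, methoxy or trifluoromethyl at this same place would give. Also open, from the compounds shown here alone, is whether fluoro at this place would change the result for compound 2, which stands at 0%.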